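The source may hold more compounds than are shown below. What is called first, only, known or untested is meant among the compounds shown, and "the series" means these compounds.

Compounds measured so far in a physicochemical assay for lipophilicity, read by HPLC (a higher number here means a more lipophilic compound, a lower number a more polar compound), are these
- Compound 1 `CN(C)Cc1ccc(NC(=O)Nc2cccnc2Oc2ccccc2C(C)(C)C)c(F)c1` gives 4.2
- Compound 2 `CC(C)(C)c1ccccc1Oc1ncccc1NC(=O)Nc1ccc(OCC2CCN(Cc3ccccc3)CC2)cc1F` gives 5.8
- Compound 3 `CC(C)N1CCC(COc2ccc(NC(=O)Nc3cccnc3Oc3ccccc3C(C)(C)C)c(F)c2)CC1` gives 3.8

Compound 3 stands lowest of the three at 3.8 and is the starting point here. Compound 4 `CC(C)CCN1CCC(COc2ccc(NC(=O)Nc3cccnc3Oc3ccccc3C(C)(C)C)c(F)c2)CC1` differs from it in one place, with isopentyl in place of isopropyl on an amine nitrogen in a ring and the rest of the molecule unchanged.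

The most relevant measured step is a number 2.00 log units lower from compound 2 to compound 3 (beyond the scatter) and it is large. It swaps benzyl for isopropyl on that same ring nitrogen, so read backwards it shows a higher number with benzyl there. The other step, a number 0.40 log units lower from compound 1 to compound 3 (beyond the scatter) is modest and replaces a group on an aromatic carbon instead, so it says little about this change. Among the compounds with values here, with only one comparison at this nitrogen, no general pattern can be claimed.

Isopentyl is a carbon chain with no ring, so only part of the benzyl step is expected here, in the same upward direction. The expected change is a number 0.80 log units higher from compound 3 to compound 4 (beyond the scatter) and would be moderate in size. For compound 4 the estimated value is 4.6 with a likely range from 4.2 to 5.1 in this assay once it is measured.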

Compound 4, partition coefficient: 5.5
Compound 4: middle estimate off by 0.90 log units, on the low side, and the stated range ends below it.
By their numbers in this assay, from the lowest: compound 3; then compound 1; then compounds 4 and 2 (each within the scatter of the next).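

At this ring nitrogen, a carbon chain with no ring can move the number as much as the benzyl group did: going from isopropyl, with 3 carbons, to isopentyl, with 5 carbons, gives a number 1.70 log units higher from compound 3 to compound 4 (beyond the scatter) in this assay and so shows that a small change in an open chain can produce a large step. The comparison with the benzyl compound reads a number 0.30 log units lower from compound 2 to compound 4 (within the scatter) and so the two compounds cannot be told apart here, which means a ring in this group is not needed to reach the level of compound 2. Nothing measured here explains why these two extra carbons count for so much, and the size of the step remains an observation without a cause.

The compounds shown leave open whether the number climbs evenly with chain length or jumps at one point, which a straight butyl or pentyl chain on the same nitrogen would help to show. They also leave open how far a hydroxyl group or an ether oxygen within the isopentyl chain would bring the number back down.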